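Trimming an Ethyl to a Methyl on the Pyridine

A few compounds are considered here, and "the series" means these few. Any claim that something is new, unique, unknown or untested is made for them only; others in the source may bear on it.

Compound 1 `Cc1cccc(-c2nn3c(c2-c2ccncc2)CC(C)(C)C3)n1`, compound 2 `Cc1cccc(-c2nn3c(c2-c2ccncc2)C(CO)C(C)(C)C3)n1` and compound 3 `CCc1cccc(-c2nn3c(c2-c2ccncc2)C(C)C(C)(C)C3)n1` share one core. In a functional assay on K562 cells (Homo sapiens) for cytotoxicity, with a stated time of 72 h (on this read-out lower numbers stand for stronger inhibition and higher numbers for weaker inhibition), compound 1 gives only a limit, > 100000 nM. Compound 2 likewise reaches only a limit, > 100000 nM, in this assay. Compound 3 too stands at a limit, > 100000 nM, in this assay. The step that the two limits leave unreadable from compound 1 to compound 2, hydroxymethyl in place of hydrogen on a saturated ring carbon, cannot be read between two limits. Every value sits at the same limit (the limit of > 100000 nM in this assay, at which 3 of the 3 values shown sit). Compound 4 `Cc1cccc(-c2nn3c(c2-c2ccncc2)C(C)C(C)(C)C3)n1` differs from compound 3 by hydrogen in place of methyl on a saturated chain carbon bound to an aromatic carbon. Among the measured compounds shown here, no measured step tracks this ethyl to methyl change, and no measured compound shows a readable number, so no step beyond the scatter is expected. Compound 4 is therefore expected to give 150000 nM, within 50000 nM to 1000000 nM, in this assay. The expected step is a step that the limit leaves unreadable from compound 3 to compound 4.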

Compound 4, half-maximal inhibitory concentration: > 100000 nM
Compound 4 gave a limit, no number (the forecaster's own chance of this, stated with the estimate: 85%); the middle value does not contradict the limit.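

Compound 4 also gives only a limit, so its steps from compound 1, compound 2 and compound 3 cannot be read: the limit of > 100000 nM in this assay, at which 4 of the 4 values shown sit. The compounds shown leave open what size, if any, these changes have in this assay.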